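The source may hold more compounds than are shown below. What is called first, only, known or untested is meant among the compounds shown, and "the series" means these compounds.

Compound 1 `COc1ccc(C2N=C(SCc3ccccc3)NC(C)=C2C(=O)Nc2ccc(F)cc2)cc1OC` gives 12.9% in a functional assay on the whole organism (artery, strain albino) with Rattus norvegicus as the target, with a stated time of 180 min, at a dose of 10 mg/kg by the oral route; a higher number here means more inhibition at the dose given (going by the name of the read-out), a lower number less inhibition. Compound 2 `COc1ccc(C2N=C(SCc3cccc(Cl)c3)NC(C)=C2C(=O)Nc2ccc(F)cc2)cc1OC` carries the change chloro in place of hydrogen on an aromatic carbon and in this assay gives 13.4%, a step of a number 0.5 percentage points higher from compound 1 to compound 2 (within the scatter). Compound 3 `CC1=C(C(=O)Nc2ccc(Br)cc2)C(c2ccc(Cl)cc2Cl)N=C(SCc2ccccc2)N1` rests on a different core; how its core differs from that of compound 1 is not broken down here. In this assay compound 3 gives 13.4%, level with compound 2 at the digits shown and within the scatter of compound 1.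

Compound 4 `CC1=C(C(=O)Nc2ccc(Br)cc2)C(c2ccc(Cl)cc2Cl)N=C(SCc2ccccc2Cl)N1` carries, relative to compound 3, the change (chloro in place of hydrogen on an aromatic carbon). It is the same kind of change as that from compound 1 to compound 2, though not the same: there the chloro sits meta to a large group, here ortho to a large group. Because a number 0.5 percentage points higher from compound 1 to compound 2 (within the scatter) stayed within the scatter, compound 4 is expected to move by about a number 0.6 percentage points higher from compound 3 to compound 4 (within the scatter). Compound 4 is therefore estimated at 14%, between 5% and 25%.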

Compound 4, a percentage reported as inhibition, in the whole organism at one dose (the size of the read-out at that dose, not a potency): 22.2%
Compound 4: middle estimate off by 8.2 percentage points, on the low side; measured number inside the range.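

Chloro in place of hydrogen on an aromatic carbon gives, in this assay, a number 8.8 percentage points higher from compound 3 to compound 4 (within the scatter). Set beside the earlier step, the change shows no difference between the two cores that can be told apart: the same change on two cores in this assay, a number 0.5 percentage points higher (within the scatter) from compound 1 to compound 2 and a number 8.8 percentage points higher (within the scatter) from compound 3 to compound 4, 8.3 percentage points apart, within the scatter of two such steps This does not show that the change acts alike on both cores, nor that it has any effect at all: both steps lie within the scatter, only two pairs stand, and the chloro of compound 4 sits ortho to a large group, whereas that of compound 2 does not.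

Open, on these data alone, is how 2-chlorobenzyl itself would read on the core of compound 1. Also open, as far as these compounds go, is what an amine, a carboxylic acid or a longer chain would do in place of the benzyl group.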